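A few compounds are considered here, and "the series" means these few. Any claim that something is new, unique, unknown or untested is made for them only; others in the source may bear on it.

Working notes on the fluoro-cyanobenzamide series.

Three members of the series carry measurements in an in vitro functional assay on HEK293-A cells for antagonist activity at metabotropic glutamate receptor 5 (Rattus norvegicus), read by calcium flux; a lower number here means a stronger inhibitor, a higher number a weaker inhibitor. Compound 1 `Cc1nc(NC(=O)c2cc(F)cc(C#N)c2)sc1C` gives 594 nM in this assay. Compound 3 `Cc1cccc(NC(=O)c2cc(F)cc(C#N)c2)c1` gives 122 nM in this assay. Compound 2 `N#Cc1cc(F)cc(C(=O)Nc2ccccc2Cl)c1` returns only a limit in this assay, > 30000 nM, and not a number; this is the limit of > 30000 nM in this assay, at which 1 of the 3 values shown sits.

Among the two numbers reported, compound 3 stands lowest; the nearest number belongs to compound 1, and the gap between compound 3 and compound 1 lies beyond the scatter of repeated measurements. Within the data shown here, no pair of the measured compounds differs in a single place, so no measured step is available to anchor a prediction.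

The next member, compound 4 `CCc1cccc(NC(=O)c2cc(F)cc(C#N)c2)c1`, differs from compound 3 by methyl in place of hydrogen on a saturated chain carbon bound to an aromatic carbon. Among the measured compounds shown here, the change is a single carbon added to the substituent on the anilide ring, and no measured pair speaks to a change of this kind. The step from compound 3 to compound 4 is therefore expected to be small, in either direction, and is estimated at a 1.2-fold higher number from compound 3 to compound 4 (0.09 log units; within the scatter), which would not leave the scatter. On that basis compound 4 is estimated at 150 nM in this assay, with a range from 50 nM to 450 nM.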

Compound 4, half-maximal inhibitory concentration: 4940 nM
Estimate against measurement, compound 4: 33-fold (1.52 log units) below, outside the stated range (above it).
By their numbers in this assay, from the lowest: compound 3; then compound 1; then compound 4. At a limit, above all of these: compound 2.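

Among these compounds, the step from methyl to ethyl is the first single-place comparison, and it is far from neutral: in this assay the change gives a 40-fold higher number from compound 3 to compound 4 (1.61 log units; beyond the scatter) for one added carbon on the substituent of the anilide ring. At this position, then, the size of a change cannot be judged from its heavy-atom count, and the methyl of compound 3 cannot be treated as a freely extendable point on the shared core, at least for this one pair. None of the information at hand bears on why so small a change has so large an effect.

The compounds shown leave open whether the number keeps rising, levels off or falls back with a longer chain such as propyl, and whether a branched group such as isopropyl or a methoxy group at the same place behaves like methyl or like ethyl. From the compounds shown here alone, with a single step at this position, it also remains open whether the same addition would carry a similar penalty elsewhere on the anilide ring.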